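Trifluoromethoxy to Trifluoroethoxy on a Cyclopropane Hydrazide

This account rests on a few compounds, and the source may have more. Where it says the series, first, only, none or still open, it means among the compounds named here.

Measured compounds:
compound 1 `O=C(NNC(=O)C1CC1c1ccc(OC(F)(F)F)cc1)c1ccncc1` – "not determined" (no result reported)
compound 2 `O=C(NNc1nncc2ccccc12)C1CC1c1ccc(OCC(F)(F)F)cc1` – 8000 nM
compound 3 `CC(C)=CCC/C(C)=C/COc1ccc(C2CC2C(=O)NNc2nncc3ccccc23)cc1` – 23000 nM

In a functional assay on MCF7 cells (Homo sapiens) for inhibition, read by MTT assay, with a stated time of 72 h (a lower number here means a stronger inhibitor, a higher number a weaker inhibitor), compound 1 gives "not determined" (no result reported), so it has no number to stand on. Compound 4 `O=C(NNC(=O)C1CC1c1ccc(OCC(F)(F)F)cc1)c1ccncc1` differs from compound 1 by 2,2,2-trifluoroethyl in place of trifluoromethyl on an oxygen on an aromatic ring. For the measured compounds named here, no measured step matches this exact change. Going by the values given here, the one measured step, a 2.9-fold higher number from compound 2 to compound 3 (0.46 log units; beyond the scatter), alters the same oxygen-bound chain but on a different core, and it is modest. Compound 2 already carries the 2,2,2-trifluoroethyl group that enters here, and in this assay compound 2 gives 8000 nM, which is the nearest guide available. With no value for compound 1, neither the size nor the direction of the step can be expected with confidence. Compound 4 is estimated at 12000 nM, with a range from 3000 nM to 50000 nM.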

Compound 4, half-maximal inhibitory concentration: 34000 nM
For compound 4 the middle estimate is 2.8-fold (0.45 log units) below the measured one; the range from low to high includes it.
By their numbers in this assay, from the lowest: compound 2; then compounds 3 and 4 (each within the scatter of the next).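

For the compounds shown here, compound 1 has no number to compare, so no step from it to compound 4 can be read. Going by these compounds, whether trifluoromethoxy to 2,2,2-trifluoroethoxy raises or lowers the number stays open, and no supporting evidence bears on the result.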